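Swapping an Aromatic Iodo for Hydroxymethyl

The source may report more compounds than this note shows. Statements on the series, on what has been measured and on what is new or still open speak of the compounds shown alone.

Three measured compounds share one core and differ only in the groups on the aromatic ring. Compound 1 `O=C(CCCCCc1cccc(I)c1)N1CCOC1=O` carries an iodo group, and in an assay on HEK293 cells for inhibition of N-acylethanolamine-hydrolyzing acid amidase (Rattus norvegicus), read by LC-MS, with a stated time of 30 min (a higher number here means a weaker inhibitor, a lower number a stronger inhibitor), compound 1 gives 3120 nM. Compound 3 `O=C(CCCCCc1ccc(O)c(F)c1)N1CCOC1=O` carries fluoro and hydroxy groups, and in this assay compound 3 gives 160 nM. Compound 2 `O=C(CCCCCc1ccc(O)c(Cl)c1)N1CCOC1=O` has chloro where compound 3 has fluoro; in this assay compound 2 reaches only > 20000 nM, a limit of the assay rather than a number (the limit of > 20000 nM in this assay, at which 1 of the 3 values shown sits). That single swap gives an at least 120-fold lower number from compound 2 to compound 3 (2.09 log units; beyond the scatter). Of the two numbers shown, compound 1 stands highest, with compound 3 the nearest.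

Compound 4 `O=C(CCCCCc1cccc(CO)c1)N1CCOC1=O` differs from compound 1 by hydroxymethyl in place of iodo on an aromatic carbon. For the measured compounds named here, no measured step exchanges a halogen for a hydroxymethyl group; the one measured step exchanges one halogen for another, so it bears only loosely on this change. The step from compound 1 to compound 4 is therefore expected to be a 1.0-fold lower number from compound 1 to compound 4 (0.02 log units; within the scatter), within or near the scatter. Compound 4 is expected to give 3000 nM, in a range from 600 nM to 15000 nM.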

Compound 4, half-maximal inhibitory concentration: > 20000 nM
Compound 4 was reported as a limit; the forecaster's own chance of this, stated with the estimate: 15%; middle value at least 6.6-fold (0.82 log units) from the limit.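

On the aromatic carbon meta to a large group, hydroxymethyl in place of iodo is no neutral exchange in this assay: it gives an at least 6.4-fold higher number from compound 1 to compound 4 (0.80 log units; beyond the scatter). For the compounds shown here, the only earlier step swapped one halogen for another, whereas this one replaces a halogen with a group carrying 1 hydrogen-bond donor and 1 hydrogen-bond acceptor, and the inhibitor becomes clearly weaker. The reading for compound 4 is a limit of the assay and not a number, and compound 2 stands at the same limit: the limit of > 20000 nM in this assay, at which 2 of the 4 values shown sit.

Going by these compounds, whether an amine, a carboxylic acid or a methoxy group on this same carbon would read closer to compound 1 or to compound 4 stays open. Also open, on these data alone, is whether the same loss would appear on a ring carrying the fluoro and hydroxy groups of compound 3.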